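The source may report more compounds than this note shows. Statements on the series, on what has been measured and on what is new or still open speak of the compounds shown alone.

Compound 1 `CN(Cc1ccc(OCCCN)cc1)c1nc2ccc(Oc3ccc(C#N)cc3)cc2s1` was tested in an assay on cells for inhibition of Voltage-dependent T-type calcium channel subunit alpha-1H (Homo sapiens), read by FLIPR and calcium flux, with stated times of 600 s and 300 s (a lower number here means a stronger inhibitor, a higher number a weaker inhibitor), where compound 1 gives 328000 nM. Two further compounds of the same series share its core. Compound 2 `CN(Cc1ccc(OCCCNC(=N)N)cc1)c1nc2ccc(Oc3ccc(C(F)(F)F)cc3)cc2s1` gives 212000 nM in this assay, and compound 3 `CN(Cc1ccc(OCCCNC(=N)N)cc1)c1nc2ccc(Oc3ccc(O)cc3)cc2s1` gives 332000 nM. All three numbers lie within the usual scatter of one another, so compound 1 cannot be set apart from compound 2 or compound 3 on these figures. Going by the values given here, the one single-point step available, a 1.6-fold higher number from compound 2 to compound 3 (0.19 log units; within the scatter), changes the group on the oxygen on the aromatic ring and stays within the scatter.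

Compound 4 `CN(Cc1ccc(OCCCN)cc1)c1nc2ccc(Oc3cccc(C(F)(F)F)c3)cc2s1` has not yet been measured in this assay. It differs from compound 1 by 3-(trifluoromethyl)phenyl in place of 4-cyanophenyl on an oxygen on an aromatic ring. Among the compounds with values here, no measured pair isolates exactly this exchange; compound 1 and compound 2 differ in two places, and their two values are within the scatter of each other. The step from compound 2 to compound 3, at the same place, was also within the scatter. On that basis compound 4 is expected to sit close to compound 1, with an estimated step of a 1.1-fold lower number from compound 1 to compound 4 (0.04 log units; within the scatter) that does not reach beyond the scatter. The estimate for compound 4 is 300000 nM, with a range from 100000 nM to 900000 nM.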

Compound 4, half-maximal inhibitory concentration: 239000 nM
Beside the measured number, compound 4's estimate is 1.3-fold (0.10 log units) above it, and the stated range covers the measured number.
By their numbers in this assay, from the lowest: compounds 2, 4, 1 and 3 (each within the scatter of the next).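

In this assay, the exchange of 4-cyanophenyl for 3-(trifluoromethyl)phenyl on an oxygen on an aromatic ring gives a 1.4-fold lower number from compound 1 to compound 4 (0.14 log units; within the scatter). Going by these compounds alone, this is the first step at this place read with the side chain of compound 1 held fixed, and it shows that removing the nitrile and bringing in a trifluoromethyl group, with the number printed in the group's name also changing, does not separate the two compounds on these figures. Nothing measured here accounts for this result.

The exchange alters both the group and its printed ring position at once, so the compounds shown cannot tell whether either change alone would leave the number within the scatter. On these data alone, it also remains open whether a carboxylic acid or a methoxy group on the same aromatic ring, or a longer chain in place of the one ending in the amine, would give a step beyond the scatter in this assay.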